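The compounds below may be only part of what the source reports. "The series", "measured", "known", "first", "only" and "open" are said of these compounds alone.

Of the compounds shown here, three sharing one core have been tested in an ADME assay on a cell-free system (plasma, Homo sapiens) for protein binding, using equilibrium dialysis, with a stated time of 5 h, tested at 10 uM; on this read-out lower numbers stand for a smaller free fraction and higher numbers for a larger free fraction. Compound 1 (`CC[C@@H](c1ccc(C(=O)O)c(Oc2cccc(Cl)c2)c1F)N1CCC[C@H](n2cc(C)c(=O)[nH]c2=O)C1`) gives 0.011, and compound 2 (`CC[C@H](c1ccc(C(=O)O)c(Oc2cccc(Cl)c2)c1OC)N1CCC[C@H](n2cc(C)c(=O)[nH]c2=O)C1`) gives 0.015, two numbers within the usual scatter of each other. Compound 3 (`CCC[C@@H](c1ccc(C(=O)O)c(Oc2cccc(Cl)c2)c1OC)N1CCC[C@H](n2cc(C)c(=O)[nH]c2=O)C1`) gives 0.065, the highest of the three, and its distance to each of the others lies beyond the scatter.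

The next compound, compound 4 (`CC[C@@H](c1ccc(C(=O)O)c(Oc2cccc(Cl)c2)c1OC)N1CCC[C@H](n2cc(C)c(=O)[nH]c2=O)C1`), departs from compound 3 by a single change: hydrogen in place of methyl on a saturated chain carbon, three bonds along the chain from an amine nitrogen in a ring and an aromatic carbon. Hydrogen takes the place of methyl on a saturated chain carbon, three bonds along the chain from an amine nitrogen in a ring and an aromatic carbon, so that propyl becomes ethyl.

Going by the values given here, no measured pair shows this change on its own, so the expectation rests on indirect evidence. The two tested compounds with ethyl lie low, with compound 1 at 0.011 and compound 2 at 0.015, but these values offer only limited guidance. In this assay, a modest fall in the free fraction, about the size of the scatter, is therefore expected. The estimated change is a 2.2-fold lower number from compound 3 to compound 4 (0.34 log units; beyond the scatter). For compound 4 the expected value is 0.03, with an estimated range from 0.012 to 0.07.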

Compound 4, unbound fraction in the plasma assay: 0.11
Compound 4: middle estimate off by 3.7-fold (0.56 log units), on the low side, outside the stated range (above it).
By their numbers in the plasma assay, from the lowest: compounds 1 and 2 (each within the scatter of the next); then compounds 3 and 4 (each within the scatter of the next).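

Shortening propyl to ethyl at this carbon proves to be a small change: in the plasma assay the result is a 1.7-fold higher number from compound 3 to compound 4 (0.23 log units; within the scatter), and in a physicochemical assay for lipophilicity, using the shake flask method, in phosphate buffer, measured as octanol-water partition, at pH 7.4 (a lower number here means a more polar compound, a higher number a more lipophilic compound), where compound 3 gives 0.13 and compound 4 gives -0.02, it is a number 0.15 log units lower from compound 3 to compound 4 (within the scatter), so neither read-out separates the two chain lengths. The far larger step in the plasma assay lies at the stereocentre on the same saturated chain carbon, a 7.3-fold higher number from compound 2 to compound 4 (0.87 log units; beyond the scatter), and with the ethyl chain held constant it can be ascribed to the drawn configuration alone, by this fact: the fact that compounds 2 and 4 differ only in the configuration as drawn. Configuration does not settle the free fraction on its own, however, since the aromatic substituent also matters in the plasma assay, with methoxy in place of fluoro giving a 10-fold higher number from compound 1 to compound 4 (1.00 log units; beyond the scatter).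

The compounds shown leave open whether a methyl or a butyl chain, or a branched isopropyl group, at this carbon would also stay within the scatter of ethyl and propyl, and whether the configuration step seen with ethyl would recur with propyl. They also leave open how the free fraction would respond to a chloro or an ethoxy group on the aromatic carbon that carries methoxy in compound 4.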